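The compounds below may be only part of what the source reports. "The series", "measured", "known", "first", "only" and "open" are said of these compounds alone.

Compound 1, `CC/C=C/C(=O)Nc1cccc(Oc2nc(Nc3cccc(OC)c3)nc3c2CSCC3)c1`: in an ADME assay on L02 cells (Homo sapiens) for cytotoxicity, read by MTT assay, with a stated time of 72 h (on this read-out lower numbers stand for stronger inhibition and higher numbers for weaker inhibition), compound 1 gives > 50000 nM, a limit of the assay.
Compound 2, `COc1cccc(Nc2nc3c(c(Oc4cccc(NC(=O)/C=C/C(C)C)c4)n2)CSCC3)c1`: compound 2 gives > 50000 nM, likewise a limit.
Compound 3, `CC/C=C/C(=O)Nc1cccc(Oc2nc(Nc3ccc(OC)cc3)nc3c2CSCC3)c1`: compound 3 gives > 50000 nM, again a limit.

All three measured compounds sit at the limit of > 50000 nM in this assay, at which 3 of the 3 values shown sit, so none of them yields a number. The change from compound 1 to compound 2 is methyl in place of hydrogen on a saturated chain carbon bound to a double-bonded chain carbon and a saturated chain carbon; the step it made is a step that the two limits leave unreadable from compound 1 to compound 2. The cores of the two pairs differ by 4-methoxyphenyl in place of 3-methoxyphenyl on a nitrogen on an aromatic ring, and the step between them is a step that the two limits leave unreadable from compound 1 to compound 3.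

Compound 4, `CCC/C=C/C(=O)Nc1cccc(Oc2nc(Nc3ccc(OC)cc3)nc3c2CSCC3)c1`, has not yet been measured. It arises from compound 3 by methyl in place of hydrogen on a saturated chain carbon, two bonds along the chain from a double-bonded chain carbon. Within the data shown here, this is the same kind of change as the one from compound 1 to compound 2, but not the same: there the methyl entered on a saturated chain carbon bound to a double-bonded chain carbon and a saturated chain carbon, here it enters on a saturated chain carbon two bonds along the chain from a double-bonded chain carbon.

The expectation rests on a step that the two limits leave unreadable from compound 1 to compound 2 and on (the limit of > 50000 nM in this assay, at which 3 of the 3 values shown sit). Compound 4 is expected to give 60000 nM, most likely between 30000 nM and 150000 nM. For compound 4 the expected step is a step that the limit leaves unreadable from compound 3 to compound 4, and a further limit rather than a number is expected.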

Compound 4, half-maximal inhibitory concentration: > 50000 nM
Compound 4: a limit, no number; the forecaster's own chance of this, stated with the estimate: 85%; the middle value does not contradict the limit.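

In this assay compound 4 gives > 50000 nM, a limit and not a number. Among these compounds, compound 3 and compound 4 both stand at a limit, and no step between them can be read. The compounds shown leave open what concentration each would need for half-maximal inhibition, and whether any change among them alters it: the limit of > 50000 nM in this assay, at which 4 of the 4 values shown sit.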